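The compounds below may be only part of what the source reports. "The series", "measured", "known", "first", "only" and "open" are said of these compounds alone.

Two compounds share a core and differ only in the aromatic group carried on a saturated chain carbon bound to an oxygen next to a carbonyl group. Compound 1 `COC(=O)C1=C(C)NC(C)=C(C(=O)OCc2cc([N+](=O)[O-])cc([N+](=O)[O-])c2)C1c1cccc([N+](=O)[O-])c1` carries a 3,5-dinitrophenyl there, and in a functional assay on HEK293 cells for antagonist activity at Voltage-dependent L-type calcium channel subunit alpha-1C (Oryctolagus cuniculus), read by FLIPR (on this read-out lower numbers stand for stronger inhibition and higher numbers for weaker inhibition), compound 1 gives 55 nM. Compound 2 `COC(=O)C1=C(C)NC(C)=C(C(=O)OCc2ccc(OC)cc2)C1c1cccc([N+](=O)[O-])c1` carries a 4-methoxyphenyl in the same place, and in this assay compound 2 gives 51 nM. The step of a 1.1-fold lower number from compound 1 to compound 2 (0.03 log units; within the scatter) shows that exchanging one aromatic group for another at this position left the read-out essentially unchanged. Among the two numbers compound 2 stands lowest, but its distance to compound 1 is within the scatter, so neither compound can be called the more potent.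

Compound 3 `COC(=O)C1=C(C)NC(C)=C(C(=O)OCc2ccco2)C1c1cccc([N+](=O)[O-])c1` alters the same position again: furan-2-yl in place of 4-methoxyphenyl on a saturated chain carbon bound to an oxygen next to a carbonyl group. Among the compounds with values here, the only measured step that bears on this change is the one from compound 1 to compound 2, which stayed within the scatter. For compound 3 the expected step in this assay is therefore a 1.1-fold higher number from compound 2 to compound 3 (0.03 log units; within the scatter), with no movement beyond the scatter in either direction. For compound 3 the estimate in this assay is 55 nM, within a range from 20 nM to 160 nM.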

Compound 3, half-maximal inhibitory concentration: 20 nM
Compound 3: middle estimate off by 2.8-fold (0.44 log units), on the high side; the range from low to high includes it.
By their numbers in this assay, from the lowest: compound 3; then compounds 2 and 1 (each within the scatter of the next).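

Furan-2-yl at this place, on a saturated chain carbon bound to an oxygen next to a carbonyl group, brings a 2.6-fold lower number from compound 2 to compound 3 (0.41 log units; beyond the scatter) and a 2.8-fold lower number from compound 1 to compound 3 (0.44 log units; beyond the scatter) in this assay and so shows that the read-out does respond to the aromatic group held there. The earlier pair, with its two substituted six-membered carbon rings, stayed within the scatter of each other and gave no sign of this, whereas the change here swaps such a ring for a five-membered aromatic ring with 1 hetero atom, and the heavy atoms of the group fall from 8 to 5 against 4-methoxyphenyl. Both steps are modest, and nothing measured on these compounds speaks to what lies behind them.

The compounds shown leave open whether the lower number goes with the smaller group or with the five-membered ring and its oxygen, as this one change alters both together: an unsubstituted phenyl, a thiophen-2-yl or a saturated tetrahydrofuran-2-yl would help to pull these apart. They also leave open how this place would respond to a group that is not an aromatic ring at all, such as an amine or a carboxylic acid on a longer chain.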